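Swapping the Amide Side Chain in a Clearance Series

A few compounds are considered here, and "the series" means these few. Any claim that something is new, unique, unknown or untested is made for them only; others in the source may bear on it.

Compound 1 `CN(C)C(=O)CNC(=O)c1cn(Cc2ccc(-n3cccn3)cc2)c2cccnc12`: 9.3 mL/min/kg
Compound 2 `O=C(N[C@H]1CCCC[C@@H]1O)c1cn(Cc2ccc3ncccc3c2)c2cccnc12`: 87 mL/min/kg
Compound 3 `O=C(N[C@H]1CCCC[C@@H]1O)c1cn(Cc2ccc(-c3cncnc3)cc2)c2cccnc12`: 104 mL/min/kg

In an ADME assay on liver for metabolic stability, with Liver microsome (Homo sapiens) as the target, using microsomes (a lower number here means slower removal, a higher number faster removal of the compound), compound 1 gives 9.3 mL/min/kg, the lowest of the three numbers. Compound 2 gives 87 mL/min/kg and compound 3 gives 104 mL/min/kg, and both of these stand beyond the scatter above compound 1. Compound 4 `O=C(N[C@H]1CCOC[C@@H]1O)c1cn(Cc2ccc(-n3cccn3)cc2)c2cccnc12` has not been measured in this assay yet. It differs from compound 1 in one place: 3-hydroxyoxan-4-yl in place of (dimethylcarbamoyl)methyl on an amide-type nitrogen. Within the data shown here, no measured pair shows this exact change, so the expectation rests on where compound 1 sits and on the higher numbers of compound 2 and compound 3. The expected step of a 3.2-fold higher number from compound 1 to compound 4 (0.51 log units; beyond the scatter) is upward, beyond the scatter. For compound 4 the estimate in this assay is 30 mL/min/kg, within a range from 12 mL/min/kg to 70 mL/min/kg.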

Compound 4, clearance: < 8 mL/min/kg
Compound 4: a limit, no number; the forecaster's own chance of this, stated with the estimate: 5%; middle value at least 3.7-fold (0.57 log units) from the limit.
By their numbers in this assay, from the lowest: compound 1; then compounds 2 and 3 (each within the scatter of the next). At a limit, below all of these: compound 4.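

In this assay, putting 3-hydroxyoxan-4-yl in place of (dimethylcarbamoyl)methyl on the amide-type nitrogen gives an at least 1.1-fold lower number from compound 1 to compound 4 (0.06 log units; that floor lies within the scatter). Compound 4 reads < 8 mL/min/kg, which is a limit and not a number, so this position can carry a hydroxylated six-membered ring without the number rising from that of compound 1. The size of any drop cannot be read past this limit: the limit of < 8 mL/min/kg in this assay, at which 1 of the 4 values shown sits.

The compounds shown leave open whether an amine or a carboxylic acid on this side chain would keep the number as low. The same holds for a longer chain on this nitrogen.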